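Pentylphenyl for butyl on the alkynyl arm of the E isomer

The source may hold more compounds than are shown below. What is called first, only, known or untested is meant among the compounds shown, and "the series" means these compounds.

Of the compounds shown here, two have numbers so far. Compound 1 `CCCCC#Cc1cn(C/C=C\CN2C(=O)c3ccccc3C2=O)c(=O)[nH]c1=O` and compound 2 `CCCCC#Cc1cn(C/C=C/CN2C(=O)c3ccccc3C2=O)c(=O)[nH]c1=O` share every atom and bond and differ only in the configuration drawn at the double bond. In a functional assay on HeLa cells (Homo sapiens) for antiproliferative activity, read by MTT assay, with a stated time of 3 days (a higher number here means a weaker inhibitor, a lower number a stronger inhibitor), compound 1 gives 33000 nM and compound 2 gives 89000 nM. The step of a 2.7-fold higher number from compound 1 to compound 2 (0.43 log units; beyond the scatter) rests on the fact that compounds 1 and 2 differ only in the configuration as drawn alone. For the measured compounds named here, compound 2 therefore stands at the highest of the two numbers, with compound 1 as its only neighbour.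

Compound 3 `CCCCCc1ccc(C#Cc2cn(C/C=C/CN3C(=O)c4ccccc4C3=O)c(=O)[nH]c2=O)cc1` keeps the E configuration of compound 2 and changes the arm on the triple bond: 4-pentylphenyl in place of butyl on a triple-bonded carbon. Going by the values given here, the one measured step concerns the configuration of the double bond and says nothing about the group on the triple-bonded carbon, so no measured step bears on this change. With nothing in the data to point one way or the other, the number for compound 3 in this assay is expected to stay near that of compound 2, the step of a 1.5-fold lower number from compound 2 to compound 3 (0.17 log units; within the scatter) being an estimate with a wide margin. Compound 3 is estimated at 60000 nM, within 12000 nM to 250000 nM.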

Compound 3, half-maximal inhibitory concentration: 27000 nM
Compound 3: the middle estimate sits 2.2-fold (0.35 log units) above what was measured; the range from low to high includes it.
By their numbers in this assay, from the lowest: compounds 3 and 1 (each within the scatter of the next); then compound 2.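

On the triple-bonded carbon of the E series, 4-pentylphenyl in place of butyl gives, in this assay, a 3.3-fold lower number from compound 2 to compound 3 (0.52 log units; beyond the scatter). For the compounds shown here, this is the first measured sign that the group at this place moves the number, as the earlier step concerned only the configuration of the double bond; in this assay the E series keeps its activity when butyl gives way to 4-pentylphenyl and a six-membered aromatic ring of carbon only enters, and the number improves modestly rather than being lost. Going by these compounds alone, the single step describes the change as a whole, and nothing measured in the data accounts for it.

The compounds shown leave open whether the ring or the pentyl chain on it carries the step, which a plain phenyl group or a longer straight alkyl chain on the triple-bonded carbon would help to separate. They also leave open whether the same change holds in the Z configuration, and how this assay responds when an amine or a carboxylic acid is carried on this arm.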